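This account rests on a few compounds, and the source may have more. Where it says the series, first, only, none or still open, it means among the compounds named here.

Compound 1 `CCCCOC(=O)Nc1ccc([Se]C#N)cc1` is one of two compounds that have been tested in a functional assay on HT-29 cells (Homo sapiens) for cytotoxicity, read by MTT assay, with a stated time of 72 h; a higher number here means that more compound is tolerated, a lower number that less compound is tolerated. In this assay compound 1 gives 63700 nM. For the measured compounds named here, the only other measured compound, compound 2 `CCCCCCOC(=O)Nc1ccc([Se][Se]c2ccc(NC(=O)OCCCCCC)cc2)cc1`, carries two copies of a related core joined through a selenium pair and gives 74200 nM in this assay. The two numbers lie within the usual scatter of each other, so compound 1 cannot be called more or less tolerated than compound 2; the two values are simply of the same order.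

Compound 3 `N#C[Se]c1ccc(NC(=O)Oc2ccccc2)cc1` is not yet measured. It differs from compound 1 in one place: phenyl in place of butyl on an oxygen next to a carbonyl group. Going by the values given here, no pair of measured compounds shows a step of this kind, so there is nothing in the data to say how this assay responds to such an exchange. With only the two closely agreeing values to go on, no shift beyond the usual scatter is expected in either direction. For compound 3 the expected value is 60000 nM, with a likely range from 25000 nM to 150000 nM. The step from compound 1 to compound 3 is thus estimated at a 1.1-fold lower number from compound 1 to compound 3 (0.03 log units; within the scatter), essentially no change.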

Compound 3, concentration lethal to 50% of the cells: 71700 nM
Compound 3: middle estimate off by 1.2-fold (0.08 log units), on the low side; measured number inside the range.
By their numbers in this assay, from the lowest: compounds 1, 3 and 2 (each within the scatter of the next).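

In this assay, putting phenyl in place of butyl on an oxygen next to a carbonyl group gives a change that stays within the usual scatter (a 1.1-fold higher number from compound 1 to compound 3 (0.05 log units; within the scatter)). For the compounds shown here, this is the first direct test of this position, and it shows that an open four-carbon chain and a six-membered aromatic ring of carbon only cannot be told apart in this read-out, even though the entering group is larger by heavy-atom count and brings a ring. The finding rests on this single pair on the core of compound 1, and nothing at hand explains why the two groups give such similar numbers.

Still open, going by these compounds, is whether any other group on this oxygen, such as a benzyl group, a chain ending in an amine or a chain ending in a carboxylic acid, would move the number beyond the scatter. Also open, on these data alone, is whether the exchange of butyl for phenyl would give the same small step on a core carrying the selenium pair of compound 2.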